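The compounds below may be only part of what the source reports. "The series", "measured", "known", "first", "only" and "open" are said of these compounds alone.

In an ADME assay on the whole organism (strain 129/SvEvBrd x C57BL/6) for metabolic stability, with Mus musculus as the target (a lower number here means that the compound disappears faster, a higher number that the compound lasts longer), compound 1 `CC(F)(F)c1nc([C@@H](O)[C@H](O)[C@H](O)CO)c[nH]1` gives 1 h, compound 2 `OC[C@@H](O)[C@@H](O)[C@H](O)c1c[nH]c(-c2cocn2)n1` gives 1.2 h and compound 3 `OC[C@@H](O)[C@@H](O)[C@H](O)c1c[nH]c(-c2ncccn2)n1` gives 2.4 h. Compound 3 is clearly separated from only one of the others: a 2.4-fold higher number from compound 1 to compound 3 (0.38 log units; beyond the scatter) contrasts with a 2.0-fold higher number from compound 2 to compound 3 (0.30 log units; within the scatter). Compound 4 `OC[C@@H](O)[C@@H](O)[C@H](O)c1c[nH]c(-c2ncon2)n1` carries 1,2,4-oxadiazol-3-yl in place of pyrimidin-2-yl on an aromatic carbon. For the measured compounds named here, the closest precedent is a 2.0-fold higher number from compound 2 to compound 3 (0.30 log units; within the scatter), where pyrimidin-2-yl took the place of 1,3-oxazol-4-yl, and the new change swaps in the opposite sense, from the six-membered to a five-membered aromatic ring. A similar or smaller drop is therefore expected, with a 1.7-fold lower number from compound 3 to compound 4 (0.23 log units; within the scatter) as the estimated step. For compound 4 the expected value is 1.4 h, within an estimated range of 0.7 h to 2.8 h.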

Compound 4, half-life: 0.7 h
Compound 4: the middle estimate sits 2.0-fold (0.30 log units) above what was measured; the range from low to high includes it.
By their numbers in this assay, from the lowest: compounds 4, 1, 2 and 3 (each within the scatter of the next, the first and the last beyond it).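

In this assay, for the compounds shown here, 1,2,4-oxadiazol-3-yl in place of pyrimidin-2-yl gives a 3.4-fold lower number from compound 3 to compound 4 (0.54 log units; beyond the scatter), the first exchange of one aromatic ring for another at this place to pass the scatter. Against the other two groups compound 4 is not separated, with a 1.7-fold lower number from compound 2 to compound 4 (0.23 log units; within the scatter) and a 1.4-fold lower number from compound 1 to compound 4 (0.15 log units; within the scatter), so compounds 1, 2 and 4 cannot be told apart here. Nothing at hand explains the drop from pyrimidin-2-yl.

With a single six-membered ring shown, ring size cannot be separated from the kind of ring atoms. From the compounds shown here alone, how phenyl, an amine or a carboxylic acid would fare at this place remains open.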